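The source may report more compounds than this note shows. Statements on the series, on what has been measured and on what is new or still open speak of the compounds shown alone.

Working notes on the series. All members share one core bearing a benzyloxy-substituted indole-type fragment and an acrylic acid arm; the aryl group on the double-bonded chain carbon is what varies. Compound 1 `COc1cccc(/C(=C\c2cn(C(C)=O)c3ccc(OCc4ccccc4)cc23)C(=O)O)c1` gives 45200 nM in a functional assay on A549 cells (Homo sapiens) for cytotoxicity, read by MTT assay, with a stated time of 72 h; on this read-out higher numbers stand for weaker inhibition and lower numbers for stronger inhibition. Compound 3 `COc1ccc(OC)c(/C(=C\c2cn(C(C)=O)c3ccc(OCc4ccccc4)cc23)C(=O)O)c1` adds a methoxy on that aryl ring and gives 54500 nM in this assay; the step of a 1.2-fold higher number from compound 1 to compound 3 (0.08 log units; within the scatter) lies within the scatter. On the two numbers available, compound 3 and compound 1 sit within the scatter of each other, so neither can be set above the other. Compound 2 `COc1ccc(/C(=C\c2c[nH]c3ccc(OCc4ccccc4)cc23)C(=O)O)cc1` lacks the acetyl carried by the rest; in this assay compound 2 shows "not determined" (no result reported), so it contributes no number.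

Compound 4 `COc1ccc(/C(=C\c2cn(C(C)=O)c3ccc(OCc4ccccc4)cc23)C(=O)O)cc1` is still to be measured in this assay. Relative to compound 3 the change is 4-methoxyphenyl in place of 2,5-dimethoxyphenyl on a double-bonded chain carbon bound to a carbonyl carbon and a double-bonded chain carbon. For the measured compounds named here, the only step that bears on it, a 1.2-fold higher number from compound 1 to compound 3 (0.08 log units; within the scatter), altered methoxy substitution on the same aryl ring without effect beyond the scatter, so a change beyond the scatter is not expected here either. For compound 4 the estimated value in this assay is 48000 nM, with a range from 20000 nM to 115000 nM. The expected step of a 1.1-fold lower number from compound 3 to compound 4 (0.06 log units; within the scatter) is essentially flat.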

Compound 4, half-maximal inhibitory concentration: > 100000 nM
Compound 4: a limit, no number; the forecaster's own chance of this, stated with the estimate: 10%; middle value at least 2.0-fold (0.31 log units) away from the limit.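

In this assay compound 4 gives > 100000 nM, which is a limit of the assay and not a number. With 4-methoxyphenyl in place of 3-methoxyphenyl, the series shows an at least 2.2-fold higher number from compound 1 to compound 4 (0.34 log units; beyond the scatter), so a change of aryl group on this double-bonded chain carbon now reaches beyond the scatter, which a 1.2-fold higher number from compound 1 to compound 3 (0.08 log units; within the scatter) did not. With 4-methoxyphenyl in place of 2,5-dimethoxyphenyl, the series shows an at least 1.8-fold higher number from compound 3 to compound 4 (0.26 log units; that floor lies within the scatter), and with that floor inside the scatter, this step alone sets no order between the two compounds.

Compound 2 has no number, so the step to compound 4, which carries the acetyl, cannot be read. Every aryl group shown carries only methoxy, so the outcome for an aryl group bearing an amine or a carboxylic acid on this carbon remains open.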